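Swapping the amide amine in a dihydroxy acid series

This account rests on a few compounds, and the source may have more. Where it says the series, first, only, none or still open, it means among the compounds named here.

Going by the values given here, compound 1 `CC(C)c1c(C(=O)N2CCC[C@H](c3ccccc3)C2)nn(-c2ccc(F)cc2)c1OC[C@@H](O)C[C@@H](O)CC(=O)O` gives 1110 nM in a functional assay on L6 cells (Rattus norvegicus) for inhibition (on this read-out higher numbers stand for weaker inhibition and lower numbers for stronger inhibition), the lowest of the two numbers known. Compound 2 `COc1cccc(CNC(=O)c2nn(-c3ccc(F)cc3)c(OC[C@@H](O)C[C@@H](O)CC(=O)O)c2C(C)C)c1` gives 8750 nM; the step of a 7.9-fold higher number from compound 1 to compound 2 (0.90 log units; beyond the scatter) came with (3-methoxybenzyl)amino in place of 3-phenylpiperidin-1-yl on a carbonyl carbon. Compound 3 `CC(C)c1c(C(=O)N(C)Cc2ccc(F)c(F)c2)nn(-c2ccc(F)cc2)c1OC[C@@H](O)C[C@@H](O)CC(=O)O` differs from compound 1 by (3,4-difluorobenzyl)(methyl)amino in place of 3-phenylpiperidin-1-yl on a carbonyl carbon. This again removes 3-phenylpiperidin-1-yl for a benzyl-bearing amine, so a loss of similar kind, though perhaps smaller, is expected: a 3.2-fold higher number from compound 1 to compound 3 (0.50 log units; beyond the scatter). For compound 3 the estimate is 3500 nM, between 1200 nM and 10000 nM.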

Compound 3, half-maximal inhibitory concentration: 4570 nM
Beside the measured number, compound 3's estimate is 1.3-fold (0.12 log units) below it, and the stated range covers the measured number.
By their numbers in this assay, from the lowest: compound 1; then compounds 3 and 2 (each within the scatter of the next).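

In this assay, going by these compounds alone, a second benzyl-bearing amine also falls short of the 3-phenylpiperidin-1-yl amide, a 4.1-fold higher number from compound 1 to compound 3 (0.61 log units; beyond the scatter), so the loss is not tied to the single amine in compound 2. The two benzyl-bearing amines cannot be told apart, a 1.9-fold lower number from compound 2 to compound 3 (0.28 log units; within the scatter), even though they differ in the methyl on the amide nitrogen and in their ring substituents. Nothing measured here explains the advantage of compound 1.

Going by these compounds, it remains open whether the phenyl or the piperidine ring matters more; a plain piperidin-1-yl amide would help separate the two.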